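This account rests on a few compounds, and the source may have more. Where it says the series, first, only, none or still open, it means among the compounds named here.

Measured compounds:
- Compound 1, `Cc1nc2c(OCc3ccc(F)cc3)cccn2c1N`: in a functional assay on the whole organism with Rattus norvegicus as the target, at a dose of 40 mg/kg by the intraperitoneal route (a higher number here means more inhibition at the dose given (going by the name of the read-out), a lower number less inhibition), compound 1 gives 95%
- Compound 2, `Cc1nc2c(CCc3ccccc3)cccn2c1N`: in this assay compound 2 gives 47%

For the measured compounds named here, compound 2 stands lowest of the two numbers measured in this assay; the only other value, that of compound 1, lies higher by a margin beyond the usual scatter, and as the two structures differ in more than one place, nothing more can be drawn from that pair than what the two values show.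

Compound 3, `CSc1c(C)nc2c(CCc3ccccc3)cccn12`, has not yet been measured. It departs from compound 2 in a single place: methylsulfanyl in place of amino on an aromatic carbon. Methylsulfanyl replaces amino on an aromatic carbon of a five-membered aromatic ring with two nitrogens, part of a fused system of two rings.

Going by the values given here, no measured pair shows what this exchange does, so any expectation rests on compound 2 alone. The step from compound 2 to compound 3 in this assay is expected to be modest, a number 7 percentage points lower from compound 2 to compound 3 (within the scatter), with a lean towards less inhibition but no firm direction. Compound 3 is therefore estimated at 40%, within a range from 10% to 70%.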

Compound 3, a percentage reported as inhibition, in the whole organism at one dose (the size of the read-out at that dose, not a potency): 28%
Compound 3: the middle estimate sits 12 percentage points above what was measured; the measured number falls inside the stated range.
By their numbers in this assay, from the lowest: compound 3; then compound 2; then compound 1.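

In this assay, for the compounds shown here, the exchange gives the first step that can be read at a single place: a number 19 percentage points lower from compound 2 to compound 3 (beyond the scatter). The aromatic carbon that carried amino in compound 2 is therefore not indifferent to what it bears, although compound 3, with methylsulfanyl there, still gives 28%, so inhibition at the dose given does not vanish when amino leaves. Amino brings a hydrogen-bond donor and methylsulfanyl brings none, while each brings a hydrogen-bond acceptor, but this remains a count of what changed, and no measurement here explains the step.

Going by these compounds alone, the single exchange cannot separate the loss of amino from the arrival of methylsulfanyl: a methylamino, methoxy or ethyl group, or a plain hydrogen, on this same carbon would help to tell which part of the change matters. Also open, on these data alone, is whether methylsulfanyl in place of amino would give a similar step on compound 1, which gives 95% and carries a different group elsewhere on the core.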